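A few compounds are considered here, and "the series" means these few. Any claim that something is new, unique, unknown or untested is made for them only; others in the source may bear on it.

Compound 1 `C[C@@H]1CN(c2nnc(C(F)(F)F)o2)CCN1c1ncc(OCc2ccc(OS(C)(=O)=O)cc2F)cn1` gives 82% in a functional assay on HEK293S cells with Glucose-dependent insulinotropic receptor (Mus musculus) as the target, read by HTRF and cAMP accumulation, with a stated time of 45 min; on this read-out higher numbers stand for larger maximal responses and lower numbers for smaller maximal responses.
Compound 2 `C[C@@H]1CN(c2nnc(C(F)(F)F)o2)CCN1c1ncc(OCc2ccc(C#N)cc2C#N)cn1` gives 84% in this assay.

Compound 2 stands highest of these two numbers, but its nearest neighbour, compound 1, lies close: a number 2 percentage points higher from compound 1 to compound 2 (within the scatter), so the two cannot be told apart.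

Compound 3 `C[C@@H]1CN(c2nnc(C(F)(F)F)o2)CCN1c1ncc(OCc2ccc(CS(C)(=O)=O)cc2)cn1` has not yet been measured. It differs from compound 2 in one place: 4-((methylsulfonyl)methyl)phenyl in place of 2,4-dicyanophenyl on a saturated chain carbon bound to an oxygen on an aromatic ring.

Among the compounds with values here, the only measured step that bears on this is the one from compound 1 to compound 2, where the group on the saturated chain carbon bound to an oxygen on an aromatic ring was also exchanged, and that step stayed within the scatter (a number 2 percentage points higher from compound 1 to compound 2 (within the scatter)). Both measured compounds reach a similar maximal response despite carrying quite different groups at this position, so no step beyond the scatter is expected here. The estimated step is a number 4 percentage points lower from compound 2 to compound 3 (within the scatter). In this assay compound 3 is therefore expected to give about 80%, with a range from 65% to 92%.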

Compound 3, intrinsic activity: the largest response reached, in percent of the reference agonist's: 95%
The estimate for compound 3 lay 15 percentage points below the measured number, outside the stated range (above it).
By their numbers in this assay, from the lowest: compounds 1 and 2 (each within the scatter of the next); then compound 3.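

Putting 4-((methylsulfonyl)methyl)phenyl in place of 2,4-dicyanophenyl on the saturated chain carbon bound to an oxygen on an aromatic ring gives a number 11 percentage points higher from compound 2 to compound 3 (beyond the scatter) in this assay, and putting it in place of 2-fluoro-4-((methylsulfonyl)oxy)phenyl gives a number 13 percentage points higher from compound 1 to compound 3 (beyond the scatter). So the maximal response does depend on the group here, a dependence that compound 1 and compound 2 alone did not reveal, although both steps are modest. No measurement shown explains this gain.

Going by these compounds, each exchange alters the whole substituted phenyl group at once, so it remains open whether the gain goes with the (methylsulfonyl)methyl group itself or with other differences between the phenyl groups. On these data alone, how an amine or a carboxylic acid on this phenyl ring would behave also remains open.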